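Adding a 3-chlorophenyl group to compound 1

This account rests on a few compounds, and the source may have more. Where it says the series, first, only, none or still open, it means among the compounds named here.

compound 1 `O=C(CCc1cccc2c1B(O)OC2)Nc1ccccc1` gives 30000 nM
compound 2 `O=C(CCc1cccc2c1B(O)OC2)Nc1ccc(-c2ccccc2)cc1` gives 32000 nM
compound 3 `O=C(CCc1cccc2c1B(O)OC2)Nc1cccc(-c2cccc(Cl)c2)c1` is not yet measured

Going by the values given here, these values come from an ADME assay on WI-38 cells (Homo sapiens) for cytotoxicity, read by MTT assay, with a stated time of 72 h (a lower number here means a stronger inhibitor, a higher number a weaker inhibitor), and compound 1 stands within the scatter of compound 2, the only other compound measured. Compound 3 differs from compound 1 as follows: 3-chlorophenyl in place of hydrogen on an aromatic carbon (3-chlorophenyl in place of hydrogen on an aromatic carbon, meta to a large group). Among the compounds with values here, the one measured step that bears on this change is a 1.1-fold higher number from compound 1 to compound 2 (0.03 log units; within the scatter) (phenyl in place of hydrogen on an aromatic carbon). Within the data shown here, no measured step shows what the chlorine adds. A step beyond the scatter is therefore not expected in this assay and no direction is favoured. The expected step is a 1.1-fold lower number from compound 1 to compound 3 (0.03 log units; within the scatter) (an estimate). Compound 3 is estimated at 28000 nM with an expected range from 12000 nM to 60000 nM (not yet measured).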

Compound 3, half-maximal inhibitory concentration: 58000 nM
The estimate for compound 3 lay 2.1-fold (0.32 log units) below the measured number, and the stated range covers the measured number.
By their numbers in this assay, from the lowest: compounds 1, 2 and 3 (each within the scatter of the next).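

In this assay, placing 3-chlorophenyl on an aromatic carbon, meta to a large group, gives a 1.9-fold higher number from compound 1 to compound 3 (0.29 log units; within the scatter). This shows that a ring bearing a chlorine can be added at this position to the core of compound 1 without a step beyond the scatter, as was also printed for the phenyl change, a 1.1-fold higher number from compound 1 to compound 2 (0.03 log units; within the scatter). Nothing available explains the number found for compound 3.

As far as these compounds go, what the chlorine contributes on its own remains open, since the step covers the added ring and its chlorine together. From the compounds shown here alone, it is also open whether an amine or a carboxylic acid in place of that chlorine would give a step beyond the scatter in this assay.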